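The source may report more compounds than this note shows. Statements on the series, on what has been measured and on what is new or still open speak of the compounds shown alone.

Compound 1 `COCCOC(=O)c1cc(N)c(Nc2ccc(C#N)cc2)cc1Oc1c(C)cc(/C=C/C#N)cc1C`: in a physicochemical assay for solubility, read by HPLC, in phosphate buffer, with a stated time of 4 h, at pH 7.4 (a lower number here means a less soluble compound, a higher number a more soluble compound), compound 1 gives 0.77 ug/mL.
Compound 2 `CCNC(=O)c1cc(N)c(Nc2ccc(C#N)cc2)cc1Oc1c(C)cc(/C=C/C#N)cc1C`: in this assay compound 2 gives 1.08 ug/mL.
Compound 3 `Cc1cc(/C=C/C#N)cc(C)c1Oc1cc(Nc2ccc(C#N)cc2)c(N)cc1C(=O)NCCCO`: in this assay compound 3 gives 1.01 ug/mL.

Among these three numbers, compound 3 gives the second highest, but both of its steps to the others are within the scatter: a 1.3-fold higher number from compound 1 to compound 3 (0.12 log units; within the scatter) and a 1.1-fold lower number from compound 2 to compound 3 (0.03 log units; within the scatter). Compound 4 `Cc1cc(/C=C/C#N)cc(C)c1Oc1cc(Nc2ccc(C#N)cc2)c(N)cc1C(=O)NCCC(F)F` is not yet measured. It differs from compound 3 in one place: difluoromethyl in place of hydroxymethyl on a saturated chain carbon, two bonds along the chain from an amide-type nitrogen. The step that bears most directly on this change is a 1.1-fold lower number from compound 2 to compound 3 (0.03 log units; within the scatter), made at the same chain carbon, and it is within the scatter; the steps at the carbonyl carbon, a 1.4-fold higher number from compound 1 to compound 2 (0.15 log units; within the scatter) and a 1.3-fold higher number from compound 1 to compound 3 (0.12 log units; within the scatter), are also within the scatter. Among the compounds with values here, no measured step exchanges hydroxymethyl for difluoromethyl, so the expectation rests on these small steps alone. The step from compound 3 to compound 4 is therefore expected to be small, at most slightly lower, as a 1.3-fold lower number from compound 3 to compound 4 (0.10 log units; within the scatter). For compound 4 the estimated value is 0.8 ug/mL, with a range from 0.3 ug/mL to 2 ug/mL.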

Compound 4, solubility: 6.59 ug/mL
Compound 4: middle estimate off by 8.2-fold (0.92 log units), on the low side, and the stated range ends below it.
By their numbers in this assay, from the lowest: compounds 1, 3 and 2 (each within the scatter of the next); then compound 4.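

At the saturated chain carbon, two bonds along the chain from an amide-type nitrogen, the earlier change had stayed within the scatter, whereas difluoromethyl in place of hydroxymethyl gives a step beyond it (a 6.5-fold higher number from compound 3 to compound 4 (0.81 log units; beyond the scatter)). Difluoromethyl in place of hydrogen at the same carbon also goes beyond the scatter (a 6.1-fold higher number from compound 2 to compound 4 (0.79 log units; beyond the scatter)), so this position is not indifferent to what it carries, and (3,3-difluoropropyl)amino on the carbonyl carbon also stands clear of 2-methoxyethoxy (an 8.6-fold higher number from compound 1 to compound 4 (0.93 log units; beyond the scatter)). Nothing in the data shown accounts for this rise.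

The compounds shown leave open whether fluoromethyl or trifluoromethyl in the same place would give a similar number. They also leave open how a longer chain carrying difluoromethyl, or an amine or carboxylic acid in its place, would read.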